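Bromo in place of methoxy on a sulfonyl aryl group

The source may hold more compounds than are shown below. What is called first, only, known or untested is meant among the compounds shown, and "the series" means these compounds.

In a functional assay on HL-60 cells (Homo sapiens) for cytotoxicity, read by MTT assay (a higher number here means a weaker inhibitor, a lower number a stronger inhibitor), two compounds with a shared core have been measured. Compound 1 (`Cc1ccccc1S(=O)(=O)NC(C)C1=CC(=O)c2c(O)ccc(O)c2C1=O`) gives 70 nM, and compound 2 (`COc1ccc(S(=O)(=O)NC(C)C2=CC(=O)c3c(O)ccc(O)c3C2=O)cc1`) gives 20 nM, the lower of the two numbers. Within the data shown here, the one measured step, a 3.5-fold lower number from compound 1 to compound 2 (0.54 log units; beyond the scatter), came with 4-methoxyphenyl in place of 2-methylphenyl on a sulfonyl sulfur. Compound 3 (`CC(NS(=O)(=O)c1ccc(Br)cc1)C1=CC(=O)c2c(O)ccc(O)c2C1=O`) has bromo in place of methoxy on an aromatic carbon, para to a large group: bromo in place of methoxy on an aromatic carbon. Among the measured compounds shown here, only the step to compound 2 bears on this change, and it is an indirect guide, as no measured compound carries bromo. That modest step, a 3.5-fold lower number from compound 1 to compound 2 (0.54 log units; beyond the scatter), suggests that a similarly modest change is possible here. The expected step is a 2.0-fold higher number from compound 2 to compound 3 (0.30 log units; within the scatter), towards a higher number. Compound 3 is expected at 40 nM, with an estimated range of 15 nM to 110 nM.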

Compound 3, half-maximal inhibitory concentration: 100 nM
The estimate for compound 3 lay 2.5-fold (0.40 log units) below the measured number; the range from low to high includes it.
By their numbers in this assay, from the lowest: compound 2; then compounds 1 and 3 (each within the scatter of the next).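

In this assay the change from 4-methoxyphenyl to 4-bromophenyl gives a 5.0-fold higher number from compound 2 to compound 3 (0.70 log units; beyond the scatter), so the group at this place, para to a large group, affects the number on its own; the earlier step had changed the substituent and its place together. Against the 2-methylphenyl group, 4-bromophenyl gives a 1.4-fold higher number from compound 1 to compound 3 (0.15 log units; within the scatter), so a substituent at this place is not enough by itself to reach the low number of compound 2. Nothing given here accounts for the difference between methoxy and bromo.

Whether methoxy stands out among groups at this place remains open, since the compounds shown include no hydroxy, ethoxy or amine there. They also leave open whether the step from methoxy to bromo keeps its size when the shared core is changed.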